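Swapping fluoro for methoxy on the amide-side ring

A few compounds are considered here, and "the series" means these few. Any claim that something is new, unique, unknown or untested is made for them only; others in the source may bear on it.

Measured compounds:
- compound 1 `COc1cc(C(=O)Nc2ccc(C(=O)/C=C/c3nc(C)c(C)nc3C)cc2)cc(OC)c1OC`: 2760 nM
- compound 2 `Cc1nc(C)c(/C=C/C(=O)c2ccc(NC(=O)c3ccc(F)cc3)cc2)nc1C`: 1540 nM
- compound 3 `Cc1ccc(C(=O)Nc2ccc(C(=O)/C=C/c3nc(C)c(C)nc3C)cc2)cc1`: 1180 nM

The three share one core, a chalcone-like linker capped by an amide, and differ only in the group on the outer benzamide ring. In a functional assay on MCF7 cells (Homo sapiens) for antiproliferative activity, read by CCK-8 assay, with a stated time of 72 h (a lower number here means a stronger inhibitor, a higher number a weaker inhibitor), compound 2 gives 1540 nM, the second highest of the three numbers; its nearest neighbour is compound 3 with 1180 nM, and the furthest is compound 1 with 2760 nM, both gaps within the scatter.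

Compound 4 `COc1ccc(C(=O)Nc2ccc(C(=O)/C=C/c3nc(C)c(C)nc3C)cc2)cc1` has not yet been measured. It differs from compound 2 by methoxy in place of fluoro on an aromatic carbon. Within the data shown here, the one comparable step measured so far, a 1.3-fold lower number from compound 2 to compound 3 (0.12 log units; within the scatter), exchanged the same fluoro for a methyl and stayed within the scatter. Compound 1, carrying three methoxy groups, gave a somewhat higher number, also within the scatter of compound 2. Among the measured compounds shown here, no step for a single methoxy is measured, so the expectation rests on these two neighbours.

The step from compound 2 to compound 4 is therefore expected to be a 1.1-fold lower number from compound 2 to compound 4 (0.04 log units; within the scatter), with no clear direction beyond the scatter. Compound 4 is estimated at 1400 nM, within 600 nM to 3200 nM.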

Compound 4, half-maximal inhibitory concentration: 1410 nM
The estimate for compound 4 lay 1.0-fold (0.00 log units) below the measured number; low and high end bracket the measured number.
By their numbers in this assay, from the lowest: compounds 3, 4, 2 and 1 (each within the scatter of the next, the first and the last beyond it).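

In this assay, replacing the 4-fluorophenyl group with the 4-methoxyphenyl group gives a 1.1-fold lower number from compound 2 to compound 4 (0.04 log units; within the scatter). Replacing methyl with methoxy at the same aromatic carbon gives a 1.2-fold higher number from compound 3 to compound 4 (0.08 log units; within the scatter), so fluoro, methyl and methoxy, para to a large group, now all lie within the scatter of one another, even though methoxy brings an oxygen counted as a hydrogen-bond acceptor, which fluoro does not. No other kind of measurement bears on this result.

From the compounds shown here alone, it remains open whether an amine, a carboxylic acid or a longer chain such as butoxy at this position would move the number beyond the scatter. It is also unknown whether one of these single groups would behave the same way elsewhere on the ring, since compounds 2, 3 and 4 all carry theirs at this one position.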